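Fluoro-to-hydrogen swap and cytotoxicity in two cores

The source may report more compounds than this note shows. Statements on the series, on what has been measured and on what is new or still open speak of the compounds shown alone.

Of the compounds shown here, three have been measured: compound 1 `N#Cc1cc2c(Oc3ccccc3OCCn3ccc(=O)[nH]c3=O)cc(F)cn2c1`, compound 2 `N#Cc1cc2c(Oc3ccccc3OCCn3ccc(=O)[nH]c3=O)cccn2c1` and compound 3 `N#Cc1ccc2c(Oc3ccc(F)cc3OCCn3ccc(=O)[nH]c3=O)cc(F)cc2c1`. A fourth, compound 4 `N#Cc1ccc2c(Oc3ccc(F)cc3OCCn3ccc(=O)[nH]c3=O)cccc2c1`, has not. In an ADME assay on MT2 cells (Homo sapiens) for cytotoxicity, read by MTT assay (on this read-out lower numbers stand for higher toxicity in this test and higher numbers for lower toxicity in this test), compound 1 gives 40000 nM. For compound 2 the read-out in this assay is a limit of the assay, > 100000 nM, and not a number. For compound 3 the same assay likewise reports only a limit, > 100000 nM.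

The change from compound 1 to compound 2 is hydrogen in place of fluoro on an aromatic carbon, and it gave an at least 2.5-fold higher number from compound 1 to compound 2 (0.39 log units; beyond the scatter). The core of compound 3 is not that of compound 1, and the difference between the two cores is not broken down here. Compound 4 is reached from compound 3 by hydrogen in place of fluoro on an aromatic carbon. For the measured compounds named here, this is the same kind of change as the one from compound 1 to compound 2, not the same one: there the place is on a six-membered aromatic ring with 1 nitrogen, two atoms from the ring nitrogen, whereas here it is on a six-membered aromatic ring of carbon only.

In this assay the step expected from the swap is a step that the limit leaves unreadable from compound 3 to compound 4. A limit rather than a number is expected again because the limit of > 100000 nM in this assay, at which 2 of the 3 values shown sit, is where compound 3 already stands and the earlier swap raised the number. The estimate for compound 4 in this assay is 150000 nM, between 60000 nM and 400000 nM.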

Compound 4, half-maximal cytotoxic concentration: > 100000 nM
Compound 4 was reported as a limit; the forecaster's own chance of this, stated with the estimate: 75%; the middle value is on the limit's open side.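

In this assay compound 4 gives > 100000 nM as a limit of the assay, not a number. Compound 3 is also reported only as a limit, so no step can be read between compound 3 and compound 4: the limit of > 100000 nM in this assay, at which 3 of the 4 values shown sit. The compounds shown leave open whether hydrogen in place of fluoro on an aromatic carbon changes the read-out at all on the core of compound 3.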